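The compounds below may be only part of what the source reports. "The series", "measured", "known", "first", "only" and "open" are said of these compounds alone.

Compound 1, `CN(C)CCCCn1c2c(c3ccccc31)C(=O)c1c[n+]([O-])c3ccccc3c1C2=O`, and compound 2, `CN1CCN(CCCn2c3c(c4ccccc42)C(=O)c2c[n+]([O-])c4ccccc4c2C3=O)CC1`, share one core and differ only in the amine at the end of the chain. In a toxicity assay on L02 cells (Homo sapiens) for cytotoxicity, read by MTT assay, with a stated time of 72 h (on this read-out higher numbers stand for weaker inhibition and lower numbers for stronger inhibition), compound 1 gives 300 nM, and compound 2 gives 230 nM; the step of a 1.3-fold lower number from compound 1 to compound 2 (0.12 log units; within the scatter) shows that these two numbers sit within the scatter of each other, so compound 2 cannot be called more or less active than compound 1.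

Compound 3, `O=C1c2c[n+]([O-])c3ccccc3c2C(=O)c2c1c1ccccc1n2CCCN1CCC(O)CC1`, is not yet measured. It differs from compound 2 by 4-hydroxypiperidin-1-yl in place of 4-methylpiperazin-1-yl on a saturated chain carbon, three bonds along the chain from an aromatic nitrogen. Among the measured compounds shown here, the only measured step at this same place, a 1.3-fold lower number from compound 1 to compound 2 (0.12 log units; within the scatter), was within the scatter, so another swap of the amine at this position is expected to leave the number about where it is. The estimated step of a 1.1-fold higher number from compound 2 to compound 3 (0.05 log units; within the scatter) is therefore expected to stay within the scatter. Compound 3 is estimated at 260 nM, with a range from 120 nM to 600 nM.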

Compound 3, half-maximal inhibitory concentration: 120 nM
Estimate against measurement, compound 3: 2.2-fold (0.34 log units) above, and the stated range covers the measured number.
By their numbers in this assay, from the lowest: compounds 3, 2 and 1 (each within the scatter of the next, the first and the last beyond it).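

In this assay, the step of a 1.9-fold lower number from compound 2 to compound 3 (0.28 log units; within the scatter) stays within the scatter, so swapping 4-methylpiperazin-1-yl for 4-hydroxypiperidin-1-yl at this place cannot be told apart from no change. Among the compounds shown here, the step of a 2.5-fold lower number from compound 1 to compound 3 (0.40 log units; beyond the scatter) is the first at this position to pass beyond the scatter, though only modestly, which shows that the amine at the end of the chain can move this number. Nothing available here explains that shift.

For the compounds shown here, with only three compounds, it remains open whether the hydroxyl matters in itself, a question that plain piperidin-1-yl or 4-methoxypiperidin-1-yl at the same place could help to settle. As far as these compounds go, it is also open whether a morpholine ring, with oxygen in the ring rather than on it, would fall with compound 3 or stay closer to compound 1.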